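Aryl variation on the shared core, next step to compound 4

The source may report more compounds than this note shows. Statements on the series, on what has been measured and on what is new or still open speak of the compounds shown alone.

Measured so far in an assay for binding affinity to dual specificity mitogen-activated protein kinase kinase 4 (Homo sapiens), read by KINOMEscan, tested at 100 nM; a higher number here means a weaker effect of the compound at the concentration tested, a lower number a stronger effect:
compound 1, `CCCS(=O)(=O)Nc1ccc(F)c(C(=O)c2n[nH]c3ncc(-c4ccccc4C)cc23)c1F`, gives 7%
compound 2, `CCCS(=O)(=O)Nc1ccc(F)c(C(=O)c2n[nH]c3ncc(-c4cccc(N)c4)cc23)c1F`, gives 1.6%
compound 3, `CCCS(=O)(=O)Nc1ccc(F)c(C(=O)c2n[nH]c3ncc(-c4ccc(C)c(C)c4)cc23)c1F`, gives 20%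

Compound 3 stands highest of the three numbers in this assay; the nearest is compound 1, lower by a number 13 percentage points higher from compound 1 to compound 3 (beyond the scatter), and the furthest is compound 2, lower by a number 18.4 percentage points higher from compound 2 to compound 3 (beyond the scatter). Compound 1 and compound 2 lie within the scatter of each other, as a number 5.4 percentage points lower from compound 1 to compound 2 (within the scatter) shows.

Compound 4, `CCCS(=O)(=O)Nc1ccc(F)c(C(=O)c2n[nH]c3ncc(-c4ccc(S(N)(=O)=O)cc4Cl)cc23)c1F`, differs from compound 3 by 2-chloro-4-sulfamoylphenyl in place of 3,4-dimethylphenyl on an aromatic carbon. All three measured steps sit at the same place of the core and swap one aryl group for another. The two steps that reach compound 3 both run upward, a number 13 percentage points higher from compound 1 to compound 3 (beyond the scatter) and a number 18.4 percentage points higher from compound 2 to compound 3 (beyond the scatter), so leaving the 3,4-dimethylphenyl of compound 3 for another aryl has so far gone with a lower number. Going by the values given here, no measured step covers a sulfamoyl or chloro group, so the size for compound 4 rests only on that spread.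

For compound 4 a modest downward step of a number 12 percentage points lower from compound 3 to compound 4 (beyond the scatter) in this assay is expected, to an estimated 8% with a range from 1% to 30%.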

Compound 4, a percentage reported as activity, at one concentration (the size of the read-out at that concentration, not a potency): 3.4%
Compound 4: the middle estimate sits 4.6 percentage points above what was measured; low and high end bracket the measured number.
By their numbers in this assay, from the lowest: compounds 2, 4 and 1 (each within the scatter of the next); then compound 3.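

In this assay, this position on the shared core takes 2-chloro-4-sulfamoylphenyl, with 11 heavy atoms and a hydrogen-bond donor, in place of the 8 carbon atoms of 3,4-dimethylphenyl, and the change gives a number 16.6 percentage points lower from compound 3 to compound 4 (beyond the scatter) without loss of effect. The comparisons with the other aryl groups separate nothing, with a number 1.8 percentage points higher from compound 2 to compound 4 (within the scatter) and a number 3.6 percentage points lower from compound 1 to compound 4 (within the scatter) placing 2-chloro-4-sulfamoylphenyl level with 3-aminophenyl and 2-methylphenyl, so that of the four aryl groups shown only the 3,4-dimethylphenyl of compound 3 stands apart, and the position accepts rings of quite different make-up. Nothing at hand accounts for this spread or for the place of compound 3.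

On these data alone, the sulfamoyl and chloro groups enter together in compound 4, so how much of the step from compound 3 goes with each of them remains open. Also open, as far as these compounds go, is how a carboxylic acid, a methanesulfonyl group or a longer chain in place of the sulfamoyl group would read in this assay at this single concentration, which gives the size of the read-out and not a potency.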